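Amide in Place of Ester on the Amine Nitrogen

This account rests on a few compounds, and the source may have more. Where it says the series, first, only, none or still open, it means among the compounds named here.

Compound 3 `COC(=O)NC1=CS(=O)(=O)O[C@@]12[C@@H](CO[Si](C)(C)C(C)(C)C)O[C@@H](n1cc(C)c(=O)n(C)c1=O)[C@@H]2O[Si](C)(C)C(C)(C)C` gives 29900 nM in a functional assay on MT4 cells (Homo sapiens) (a lower number here means that less compound is tolerated, a higher number that more compound is tolerated), which places it second highest among the three measured compounds. Compound 1 `Cc1cn([C@@H]2O[C@H](CO[Si](C)(C)C(C)(C)C)[C@@]3(OS(=O)(=O)C=C3NCCC(=O)O)[C@H]2O[Si](C)(C)C(C)(C)C)c(=O)n(C)c1=O` gives 11500 nM in this assay, and the change is a 2.6-fold higher number from compound 1 to compound 3 (0.41 log units; beyond the scatter). Compound 2 `COC(=O)CNC1=CS(=O)(=O)O[C@@]12[C@@H](CO[Si](C)(C)C(C)(C)C)O[C@@H](n1cc(C)c(=O)n(C)c1=O)[C@@H]2O[Si](C)(C)C(C)(C)C` gives 105000 nM in this assay, with a 3.5-fold lower number from compound 2 to compound 3 (0.55 log units; beyond the scatter); compound 2 thus carries the highest number of the three.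

Compound 4 `Cc1cn([C@@H]2O[C@H](CO[Si](C)(C)C(C)(C)C)[C@@]3(OS(=O)(=O)C=C3NCC(N)=O)[C@H]2O[Si](C)(C)C(C)(C)C)c(=O)n(C)c1=O` is not yet measured in this assay. It differs from compound 3 by carbamoylmethyl in place of methoxycarbonyl on an amine nitrogen. Going by the values given here, the steps that bear on this are a 3.5-fold lower number from compound 2 to compound 3 (0.55 log units; beyond the scatter) and a 2.6-fold higher number from compound 1 to compound 3 (0.41 log units; beyond the scatter), both modest and both beyond the scatter, and they show that the substituent on this amine nitrogen moves the number in either direction. The carbamoylmethyl group shares the one-carbon chain of the (methoxycarbonyl)methyl group of compound 2, so a modest upward step is expected, a 1.8-fold higher number from compound 3 to compound 4 (0.26 log units; within the scatter), though smaller than the gap to compound 2. Compound 4 is therefore estimated at 55000 nM, within 18000 nM to 150000 nM.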

Compound 4, half-maximal cytotoxic concentration: 14900 nM
Estimate against measurement, compound 4: 3.7-fold (0.57 log units) above; the measured number lies below the stated range.
By their numbers in this assay, from the lowest: compounds 1, 4 and 3 (each within the scatter of the next, the first and the last beyond it); then compound 2.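

The amino in place of methoxy on the carbonyl carbon, with the one-carbon chain kept, is the sharpest contrast at this amine nitrogen (a 7.0-fold lower number from compound 2 to compound 4 (0.85 log units; beyond the scatter)), so that chain alone does not carry the high number of compound 2. Compound 4 cannot be separated from compound 3 (a 2.0-fold lower number from compound 3 to compound 4 (0.30 log units; within the scatter)) or from compound 1 (a 1.3-fold higher number from compound 1 to compound 4 (0.11 log units; within the scatter)), although the substituents on the amine nitrogen differ among all three. Of the four compounds, only compound 2, with its (methoxycarbonyl)methyl group, stands apart in this assay. No measurement offered here accounts for this difference.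

From the compounds shown here alone, it remains open whether the high number is specific to the methyl ester or would extend to an ethyl ester. A carboxylic acid on the one-carbon chain, or a primary amide on a longer chain, would also help separate the role of chain length from that of the chain end.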